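The source may hold more compounds than are shown below. What is called first, only, known or untested is meant among the compounds shown, and "the series" means these compounds.

Three compounds share one core and differ only in the group carried on the amide nitrogen. In an assay on cells for agonist activity at vitamin D3 receptor (Homo sapiens), with a stated time of 96 h (on this read-out lower numbers stand for an effect already at smaller amounts and higher numbers for an effect only at larger amounts of compound), compound 1 `CCn1c(C(=O)NCCN(C)C)ccc1C(CC)(CC)c1ccc(OCCC(O)(CC)CC)c(C)c1` gives 82 nM. Compound 2 `CCn1c(C(=O)NCCN)ccc1C(CC)(CC)c1ccc(OCCC(O)(CC)CC)c(C)c1` gives 156 nM in this assay, and the change a 1.9-fold higher number from compound 1 to compound 2 (0.28 log units; within the scatter) is small. Compound 3 `CCn1c(C(=O)Nc2cccc(C(F)(F)F)c2)ccc1C(CC)(CC)c1ccc(OCCC(O)(CC)CC)c(C)c1` gives 5900 nM in this assay, the highest of the three numbers: the step of a 72-fold higher number from compound 1 to compound 3 (1.86 log units; beyond the scatter) and the step of a 38-fold higher number from compound 2 to compound 3 (1.58 log units; beyond the scatter) are both large.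

Compound 4 `CCC(C)C(NC(=O)c1ccc(C(CC)(CC)c2ccc(OCCC(O)(CC)CC)c(C)c2)n1CC)C(=O)OC` has not yet been measured in this assay. It differs from compound 3 by a group of 9 heavy atoms (7 carbon, 2 oxygen; no ring) in place of a group of 10 heavy atoms (7 carbon, 3 fluorine; one six-membered aromatic ring of carbon only), on an amide-type nitrogen. For the measured compounds named here, both measured steps bearing on this position show that exchanging a short chain for the 3-(trifluoromethyl)phenyl group raised the number greatly, so moving away from that ring and back to a chain, even one without an amine, is expected to bring the number down, though the chain in compound 4 is not the one in compound 1 or compound 2, so the recovery is expected to be partial. For compound 4 the estimated step is a 3.9-fold lower number from compound 3 to compound 4 (0.59 log units; beyond the scatter). Compound 4 is expected to give about 1500 nM in this assay, within a range from 300 nM to 8000 nM.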

Compound 4, half-maximal effective concentration: > 10000 nM
Compound 4 was reported as a limit; the forecaster's own chance of this, stated with the estimate: 5%; at least 6.6-fold (0.82 log units) between middle value and limit.
By their numbers in this assay, from the lowest: compounds 1 and 2 (each within the scatter of the next); then compound 3. At a limit, above all of these: compound 4.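

The value for compound 4 is a limit of the assay and not a number: the limit of > 10000 nM in this assay, at which 1 of the 4 values shown sits. Replacing the ring with a chain is therefore not enough on its own to restore the low numbers seen with the amine-bearing chains, as the group of 9 heavy atoms, which has no ring, gives two large steps: an at least 64-fold higher number from compound 2 to compound 4 (1.80 log units; beyond the scatter) and an at least 120-fold higher number from compound 1 to compound 4 (2.08 log units; beyond the scatter). The remaining step, an at least 1.6-fold higher number from compound 3 to compound 4 (0.22 log units; that floor lies within the scatter), has a floor within the scatter, so these two very different groups on the amide-type nitrogen cannot be clearly ranked, although neither matches the amine-bearing chains.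

As far as these compounds go, how far the number for compound 4 actually lies past its limit remains unknown. The compounds shown also leave open whether a chain ending in a carboxylic acid would give a low number, or whether a longer chain ending in an amine would.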